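Swapping a Pentyl Chain for a Cyanophenyl Group

The source may hold more compounds than are shown below. What is called first, only, known or untested is meant among the compounds shown, and "the series" means these compounds.

The shared core carries a side group on a saturated chain carbon bound to an amine nitrogen in a ring, and the compounds here differ only there. Compound 1 `CCCCCCN1CCC(C(=O)Nc2cc(Cl)c(N)cc2OC)CC1` carries pentyl at that position. Tested in a functional assay on the whole organism for antagonist activity, with Mus musculus as the target (on this read-out lower numbers stand for an effect already at smaller amounts and higher numbers for an effect only at larger amounts of compound), compound 1 reaches only the limit of the assay, > 10 mg/kg, so its place on the numbers shown is a limit and not a measured value. Compound 2 `COc1cc(N)c(Cl)cc1NC(=O)C1CCN(Cc2ccccc2Cl)CC1` carries 2-chlorophenyl there. In this assay compound 2 also gives only a limit, > 4 mg/kg. The step between them, a step that the two limits leave unreadable from compound 1 to compound 2, cannot be read, since the limit of > 10 mg/kg in this assay, at which 1 of the 2 values shown sits, and the limit of > 4 mg/kg in this assay, at which 1 of the 2 values shown sits, are both limits. Compound 3 `COc1cc(N)c(Cl)cc1NC(=O)C1CCN(Cc2cccc(C#N)c2)CC1` is the unmeasured member; it differs from compound 1 by 3-cyanophenyl in place of pentyl on a saturated chain carbon bound to an amine nitrogen in a ring. Within the data shown here, no measured step therefore bears on this change in a readable way, and no direction of effect can be drawn from compounds 1 and 2 in this assay. The estimate for compound 3 in this assay is 10 mg/kg, between 3 mg/kg and 30 mg/kg, with a good chance that the assay again reports only a limit. This estimate corresponds to an expected step of a number no higher from compound 1 to compound 3 (the limit leaves the size open) of no change beyond the scatter.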

Compound 3, dose for half-maximal effect: > 4 mg/kg
Compound 3: only a limit was reported; the forecaster's own chance of this, stated with the estimate: 70%; the middle value does not contradict the limit.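

In this assay compound 3 gives > 4 mg/kg, which is again a limit and not a number. Compound 1, compound 2 and compound 3 all give only limits, so neither step to compound 3 can be read. The compounds shown leave open at what dose, if any, these side groups would give a readable effect.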